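A few compounds are considered here, and "the series" means these few. Any claim that something is new, unique, unknown or untested is made for them only; others in the source may bear on it.

Compound 1 `COc1cc2ncnc(NNC(=S)NC(=O)c3ccccc3Cl)c2cc1OC` is the weaker of the two compounds measured in a functional assay on GLC82 cells (Homo sapiens) for cytotoxicity, read by MTT assay, with a stated time of 72 h; a lower number here means a stronger inhibitor, a higher number a weaker inhibitor: compound 1 gives 10000 nM, while compound 2 `O=C(NC(=S)NNc1ncnc2ccccc12)c1cccc(Cl)c1` gives 3240 nM, a lower number, with the gap beyond the usual scatter. Compound 2 carries a 3-chlorophenyl but differs from compound 1 elsewhere as well, so no single step can be read from that pair. Compound 3 `COc1cc2ncnc(NNC(=S)NC(=O)c3cccc(Cl)c3)c2cc1OC` changes compound 1 in one place: 3-chlorophenyl in place of 2-chlorophenyl on a carbonyl carbon. The step of a 2.0-fold lower number from compound 1 to compound 3 (0.30 log units; within the scatter) is expected to be a modest gain rather than a large one. Compound 3 is therefore estimated at 5000 nM, within a range of 2000 nM to 15000 nM.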

Compound 3, half-maximal inhibitory concentration: 8370 nM
Compound 3: middle estimate off by 1.7-fold (0.22 log units), on the low side; the range from low to high includes it.
By their numbers in this assay, from the lowest: compound 2; then compounds 3 and 1 (each within the scatter of the next).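

In this assay, putting 3-chlorophenyl in place of 2-chlorophenyl on a carbonyl carbon gives a 1.2-fold lower number from compound 1 to compound 3 (0.08 log units; within the scatter) and so leaves the number within the usual scatter. On this core, then, the two chlorophenyl groups cannot be told apart in this read-out. No other measurement is available to go with this result.

Going by these compounds, what stays open is whether a group other than a chlorophenyl on that carbonyl carbon, such as an amine or a longer carbon chain, would shift the number beyond the scatter.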